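Piperidine-to-piperazine exchange at the pyridine amine position

The source may report more compounds than this note shows. Statements on the series, on what has been measured and on what is new or still open speak of the compounds shown alone.

Measured so far:
compound 1 `Cn1cncc1C(OCc1nc(N2CCC(C(N)=O)CC2)c(C#N)cc1-c1cccc(Cl)c1)c1ccc(C#N)cc1` — 2100 nM
compound 2 `Cn1cncc1C(OCc1nc(N2CCC(O)CC2)c(C#N)cc1-c1cccc(Cl)c1)c1ccc(C#N)cc1` — 830 nM

For the measured compounds named here, compound 2 stands at the lowest of the two numbers in an assay on isolated protein (Bos taurus) for inhibition of geranylgeranyl transferase type-1 subunit beta (Homo sapiens); a higher number here means a weaker inhibitor, a lower number a stronger inhibitor; the only neighbour is compound 1, and the step of a 2.5-fold lower number from compound 1 to compound 2 (0.40 log units; beyond the scatter) separates them, a modest shift resting on one change at a saturated ring carbon.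

Compound 3 `CN1CCN(c2nc(COC(c3ccc(C#N)cc3)c3cncn3C)c(-c3cccc(Cl)c3)cc2C#N)CC1` is not yet measured. Relative to compound 2 it carries 4-methylpiperazin-1-yl in place of 4-hydroxypiperidin-1-yl on an aromatic carbon. Going by the values given here, no measured step exchanges the whole ring at this position; the one step that touches the same substituent, a 2.5-fold lower number from compound 1 to compound 2 (0.40 log units; beyond the scatter), swapped only a group on that ring and was modest. The exchange in compound 3 is therefore not covered by a direct precedent, and the expectation is a step no larger than the scatter, in either direction, so a 1.0-fold lower number from compound 2 to compound 3 (0.02 log units; within the scatter) is the working estimate. For compound 3 in this assay the expected value is 800 nM, with a range from 250 nM to 2500 nM.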

Compound 3, half-maximal inhibitory concentration: 2400 nM
Compound 3: the middle estimate sits 3.0-fold (0.48 log units) below what was measured; the range from low to high includes it.
By their numbers in this assay, from the lowest: compound 2; then compounds 1 and 3 (each within the scatter of the next).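

In this assay, exchanging the whole ring at this position is not neutral: 4-methylpiperazin-1-yl in place of 4-hydroxypiperidin-1-yl gives a 2.9-fold higher number from compound 2 to compound 3 (0.46 log units; beyond the scatter). Replacing 4-carbamoylpiperidin-1-yl with 4-methylpiperazin-1-yl gives a 1.1-fold higher number from compound 1 to compound 3 (0.06 log units; within the scatter), so among the three groups on this aromatic carbon next to the ring nitrogen, only the 4-hydroxypiperidin-1-yl group of compound 2 stands apart, as the strongest inhibitor of the three. The data shown offer no measured explanation for this difference.

The step from compound 2 to compound 3 changes the ring atom and its substituent together, leaving their separate contributions open. A 4-methylpiperidin-1-yl or 4-(2-hydroxyethyl)piperazin-1-yl group at this position would separate the two changes.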